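A few compounds are considered here, and "the series" means these few. Any claim that something is new, unique, unknown or untested is made for them only; others in the source may bear on it.

Values so far in a functional assay on DU-145 cells (Homo sapiens) for cytotoxicity, read by trypan blue exclusion, with a stated time of 96 h (on this read-out lower numbers stand for stronger inhibition and higher numbers for weaker inhibition), are as follows
- compound 1 `COc1cc(OC)c(/C=C/S(=O)(=O)Cc2ccc(Br)c(N)c2)c(OC)c1` at 750 nM as measured
- compound 2 `COC(=O)CCNc1cc(CS(=O)(=O)/C=C/c2c(OC)cc(OC)cc2OC)ccc1OC` at 1500 nM as measured

Compound 2 at 1500 nM and compound 1 at 750 nM lie within the usual scatter of each other, so these two values set no order. Compound 3 `COC(=O)C(Nc1cc(CS(=O)(=O)/C=C/c2c(OC)cc(OC)cc2OC)ccc1OC)c1ccccc1` has not yet been measured. It carries methoxycarbonyl)(benzyl in place of 2-(methoxycarbonyl)ethyl on a nitrogen on an aromatic ring and otherwise keeps the core of compound 2. Among the measured compounds shown here, no measured pair differs in one place, so the size of this step in this assay has no direct guide, and no step beyond the scatter is expected in either direction. The expected change is no change at the digits printed from compound 2 to compound 3 (within the scatter) on this estimate. For compound 3 the estimated value is 1500 nM with an expected range of 400 nM to 5500 nM given the lack of a direct guide.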

Compound 3, half-maximal inhibitory concentration: 75 nM
The estimate for compound 3 lay 20-fold (1.30 log units) above the measured number, and the stated range ends above it.
By their numbers in this assay, from the lowest: compound 3; then compounds 1 and 2 (each within the scatter of the next).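

In this assay, among the compounds shown here, the substituent on a nitrogen on an aromatic ring proves able to move the value: methoxycarbonyl)(benzyl in place of 2-(methoxycarbonyl)ethyl gives a 20-fold lower number from compound 2 to compound 3 (1.30 log units; beyond the scatter), a size of change that the earlier compounds, with no pair differing in one place, could not reveal. Both groups count the same hydrogen-bond donors and acceptors, so the counted differences are the added six-membered aromatic ring of carbon only and the higher heavy-atom count, and this single pair cannot separate the two. Nothing measured here bears on the cause of this step.

Going by these compounds, it remains open whether the methyl ester is needed, as a carboxylic acid or a primary amide in its place would show. Also open, on these data alone, is whether a cyclohexyl ring in place of the aromatic ring would keep the lower number.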